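From piperidin-1-yl to pyrrolidin-1-yl on compound 1

The compounds below may be only part of what the source reports. "The series", "measured", "known", "first", "only" and "open" are said of these compounds alone.

In a functional assay on A549 cells (Homo sapiens) for inhibition, read by sulforhodamine B assay, with a stated time of 48 h (a higher number here means a weaker inhibitor of growth, a lower number a stronger inhibitor of growth), compound 1 (`Cc1ccn2c(CN3CCCCC3)c(-c3ccccc3)nc2n1`) gives 4040 nM, the higher of two numbers, while compound 2 (`c1ccc(-c2nc3ncccn3c2CN2CCCCC2)cc1`) gives 260 nM for comparison. Compound 3 (`Cc1ccn2c(CN3CCCC3)c(-c3ccccc3)nc2n1`) differs from compound 1 by one change (pyrrolidin-1-yl in place of piperidin-1-yl on a saturated chain carbon bound to an aromatic carbon), with pyrrolidin-1-yl in place of piperidin-1-yl on a saturated chain carbon bound to an aromatic carbon. Among the measured compounds shown here, the only measured step, to compound 2 (a 16-fold lower number from compound 1 to compound 2 (1.19 log units; beyond the scatter)), is large but is hydrogen in place of methyl on an aromatic carbon, so it does not inform this change. No step beyond the scatter is therefore expected in this assay (a 1.2-fold lower number from compound 1 to compound 3 (0.06 log units; within the scatter)). Compound 3 is expected at 3500 nM (estimated range 1300 nM to 9000 nM).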

Compound 3, concentration for 50% growth inhibition: 4150 nM
Beside the measured number, compound 3's estimate is 1.2-fold (0.07 log units) below it; measured number inside the range.
By their numbers in this assay, from the lowest: compound 2; then compounds 1 and 3 (each within the scatter of the next).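

In this assay, among the compounds shown here, the first evidence on the amine ring comes from pyrrolidin-1-yl in place of piperidin-1-yl on the saturated chain carbon bound to an aromatic carbon (a 1.0-fold higher number from compound 1 to compound 3 (0.01 log units; within the scatter)). With the methyl kept on the core, the five-membered and six-membered rings cannot be told apart in this read-out, so this position accepts either ring without a step beyond the scatter. Nothing available gives a reason for this result.

Going by these compounds, whether the same holds on the core of compound 2, which carries hydrogen in place of that methyl, remains open. Also open, on these data alone, is how a morpholine ring or an open-chain dimethylamine would behave at this position.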